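This account rests on a few compounds, and the source may have more. Where it says the series, first, only, none or still open, it means among the compounds named here.

Compound 1 `COc1c(N2CCC3(CC2)OCCO3)c(F)cc2c(=O)c(C(=O)O)cn(C3CC3)c12` was tested in an ADME assay on Vero cells (Chlorocebus sabaeus) for cytotoxicity, read by MTT assay, with a stated time of 72 h (on this read-out lower numbers stand for stronger inhibition and higher numbers for weaker inhibition), where compound 1 gives 149000 nM. Compound 3 `COc1c(N2CCC3(CC2)OCCO3)c(F)c([N+](=O)[O-])c2c(=O)c(C(=O)O)cn(C3CC3)c12` carries nitro in place of hydrogen on an aromatic carbon and in this assay compound 3 gives 135000 nM, so the change is a 1.1-fold lower number from compound 1 to compound 3 (0.04 log units; within the scatter). Compound 2 `COc1c(N2CCc3ccccc3C2C(=O)NC(C)(C)C)c(F)cc2c(=O)c(C(=O)O)cn(C3CC3)c12` shares the acid-bearing core but its difference from compound 1 is not broken down here, and in this assay compound 2 gives "not determined" (no result reported), no result having been obtained. Compound 4 `COc1c(N2CCc3ccccc3C2C(=O)NC(C)(C)C)c(F)c([N+](=O)[O-])c2c(=O)c(C(=O)O)cn(C3CC3)c12` stands to compound 2 as compound 3 does to compound 1, through (nitro in place of hydrogen on an aromatic carbon); the surroundings of the place are the same in both cases, so it is the same change. Its step in this assay from compound 2 to compound 4 is expected to be small, resting on a 1.1-fold lower number from compound 1 to compound 3 (0.04 log units; within the scatter). Since compound 2 has no number, compound 4 in this assay is expected to give 130000 nM, between 40000 nM and 400000 nM. This expectation is anchored on compound 1, which gives 149000 nM, and on compound 3, which gives 135000 nM.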

Compound 4, half-maximal inhibitory concentration: 113000 nM
Compound 4: the middle estimate sits 1.2-fold (0.06 log units) above what was measured; the measured number falls inside the stated range.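

For the compounds shown here, no step from compound 2 to compound 4 can be read in this assay. No measured evidence bears on this result. The compounds shown leave open whether nitro in place of hydrogen changes the number in compound 2 as little as it does in compound 1.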